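This account rests on a few compounds, and the source may have more. Where it says the series, first, only, none or still open, it means among the compounds named here.

Measured so far:
- compound 1, `COc1ccc(OC)c(C(=O)/C=C/c2cccs2)c1`: 13300 nM
- compound 2, `COc1ccc(OC)c(C(=O)/C=C/c2ccc(C)s2)c1`: 1800 nM

Going by the values given here, in a functional assay on HT-29 cells (Homo sapiens) for cytotoxicity, read by MTT assay (on this read-out lower numbers stand for stronger inhibition and higher numbers for weaker inhibition), compound 2 holds the lowest of the two numbers; its nearest neighbour is compound 1, and the step of a 7.4-fold lower number from compound 1 to compound 2 (0.87 log units; beyond the scatter) is the only measured change in the set, putting methyl in place of hydrogen on an aromatic carbon.

Compound 3, `COc1ccc(OC)c(C(=O)/C=C/c2occc2Br)c1`, has not been measured in this assay. It differs from compound 2 by 3-bromofuran-2-yl in place of 5-methylthiophen-2-yl on a double-bonded chain carbon bound to a double-bonded chain carbon. Among the compounds with values here, the one measured step bears only in part: the methyl that compound 2 carries on the five-membered aromatic ring is gone in compound 3, and the step from compound 1 to compound 2 shows that removing it is worth a modest move to a higher number. As far as these compounds go, nothing measured speaks to the exchange of sulfur for oxygen in the ring or to the entering bromine, so their contribution is unknown.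

The expectation for compound 3 is therefore a move back toward compound 1, a 3.3-fold higher number from compound 2 to compound 3 (0.52 log units; beyond the scatter), with wide uncertainty. Compound 3 is estimated at 6000 nM, in the range 2000 nM to 18000 nM.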

Compound 3, half-maximal inhibitory concentration: 15200 nM
For compound 3 the middle estimate is 2.5-fold (0.40 log units) below the measured one; the range from low to high includes it.
By their numbers in this assay, from the lowest: compound 2; then compounds 1 and 3 (each within the scatter of the next).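

In this assay the position on the double-bonded chain carbon proves sensitive to the identity of the five-membered ring: putting 3-bromofuran-2-yl in place of 5-methylthiophen-2-yl gives an 8.4-fold higher number from compound 2 to compound 3 (0.93 log units; beyond the scatter) and does not keep the low number of compound 2. Against the unsubstituted ring the same group gives a 1.1-fold higher number from compound 1 to compound 3 (0.06 log units; within the scatter), so 3-bromofuran-2-yl and thiophen-2-yl cannot be told apart in this series, and of the three groups at this place only 5-methylthiophen-2-yl stands apart. No measurement on these compounds speaks to the reason for this pattern.

As far as these compounds go, the change from compound 2 to compound 3 alters the ring hetero atom, removes the methyl and brings in bromine all at once, so the share of each remains open, and a furan-2-yl without bromine or a thiophen-2-yl carrying bromine would separate them. Also open, from the compounds shown here alone, is whether the gain seen with the methyl of compound 2 extends to an ethyl group, or whether a carboxylic acid or an amine on the thiophene ring would keep it.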